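This account rests on a few compounds, and the source may have more. Where it says the series, first, only, none or still open, it means among the compounds named here.

Working notes on the series.

In an assay on HEK293 cells for binding affinity to 5-hydroxytryptamine receptor 7 (Homo sapiens), read by radioligand binding, tested at 1 uM (on this read-out lower numbers stand for less inhibition and higher numbers for more inhibition at the one concentration tested (going by the name of the read-out)), compound 1 `CN1CCCN(CCn2ccc3ccc(Br)cc32)CC1` gives 93% and compound 2 `CN1CCCN(CCn2ccc3ccc(Cl)cc32)CC1` gives 85%; the step of a number 8 percentage points lower from compound 1 to compound 2 (within the scatter) stays within the scatter. Compound 3 `CN1CCCN(CCn2ccc3ccc(O)cc32)CC1` gives 28% in this assay, the lowest of the three numbers, with a number 65 percentage points lower from compound 1 to compound 3 (beyond the scatter) and a number 57 percentage points lower from compound 2 to compound 3 (beyond the scatter), both beyond the scatter.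

Compound 4 `CN1CCCN(CCn2ccc3ccc(OCc4ccccc4)cc32)CC1` differs from compound 3 by benzyl in place of hydrogen on an oxygen on an aromatic ring. Going by the values given here, no measured step of this kind exists; the two large steps both lead from a halogen to hydroxy, so they show only that the hydroxy compound stands far below the halogen compounds. Whether the benzyl on the oxygen moves the number back toward the halogen compounds is not settled by these data. Compound 4 is therefore estimated with wide bounds, placed between the hydroxy compound and the halogen compounds: 60%, range 25% to 90%. The expected step from compound 3 to compound 4 is a number 32 percentage points higher from compound 3 to compound 4 (beyond the scatter).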

Compound 4, a percentage reported as inhibition, at one concentration (the size of the read-out at that concentration, not a potency): 28%
Estimate against measurement, compound 4: 32 percentage points above, and the stated range covers the measured number.
By their numbers in this assay, from the lowest: compounds 3 and 4 (each within the scatter of the next); then compounds 2 and 1 (each within the scatter of the next).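

In this assay the change from hydroxy to benzyloxy gives no change at the digits printed from compound 3 to compound 4 (within the scatter) so benzyl on this oxygen does not bring the number back toward the halogen compounds. The halogen steps to the new compound are as large as those to the hydroxy compound, with a number 57 percentage points lower from compound 2 to compound 4 (beyond the scatter) and a number 65 percentage points lower from compound 1 to compound 4 (beyond the scatter) so the low number at this aromatic carbon is now seen with two oxygen-linked groups, not with hydroxy alone. No supporting data are available to explain this result.

On these data alone, whether the low number goes with an oxygen on this aromatic carbon as such remains open, and methyl or an amine at the same carbon would test that. Also open, as far as these compounds go, is whether methoxy, or an ether with a longer chain, stands with compound 3 and compound 4 or with the halogen compounds.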